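A few compounds are considered here, and "the series" means these few. Any claim that something is new, unique, unknown or untested is made for them only; others in the source may bear on it.

Three amides built on one shared core have been tested in a toxicity assay on THP-1 cells (Homo sapiens) for inhibition; a higher number here means that more compound is tolerated, a lower number that less compound is tolerated: compound 1 (`CCCC(=O)Nc1ncc(-c2ccc(OC)cc2)n1C`), compound 2 (`CCC(=O)Nc1ncc(-c2ccc(OC)cc2)n1C`) and compound 3 (`COc1ccc(-c2cnc(NC(=O)c3cnco3)n2C)cc1`). Compound 1 gives > 100000 nM as a limit of the assay, not a number. Compound 2 gives > 100000 nM as a limit too. Compound 3 gives > 100000 nM as a limit as well, so it has no exact value. All three stand at the limit of > 100000 nM in this assay, at which 3 of the 3 values shown sit, and no order among them can be read.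

The next compound, compound 4 (`COc1ccc(-c2cnc(NC(=O)c3cccc(O)c3)n2C)cc1`), has not been measured. Its change from compound 3 is 3-hydroxyphenyl in place of 1,3-oxazol-5-yl on a carbonyl carbon and in words it is 3-hydroxyphenyl in place of 1,3-oxazol-5-yl on a carbonyl carbon. Among the compounds with values here, no measured compound carries this group, so the evidence is indirect.

Two measured changes touch the same carbonyl carbon. Replacing propyl gives a step that the two limits leave unreadable from compound 1 to compound 3 and replacing ethyl gives a step that the two limits leave unreadable from compound 2 to compound 3 while the chain change alone gives a step that the two limits leave unreadable from compound 1 to compound 2 as its result. None of these changes brought a compound off the limit. The expected size of the next move is a number no higher from compound 3 to compound 4 (the limit leaves the size open) and that means no change beyond the scatter in either direction. Compound 4 is therefore expected at about 100000 nM with an estimated range from 30000 nM to 200000 nM and quite possibly only a limit reported again.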

Compound 4, half-maximal cytotoxic concentration: > 100000 nM
Compound 4 was reported as a limit; the forecaster's own chance of this, stated with the estimate: 75%; the middle value lies on the limit itself.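

In this assay compound 4 gives > 100000 nM, a limit of the assay and not a number. The steps between compound 4 and compounds 1, 2 and 3 cannot be read, because all four compounds share one limit: the limit of > 100000 nM in this assay, at which 4 of the 4 values shown sit. The compounds shown leave open what the half-maximal cytotoxic concentration of each compound actually is, and whether the group on the carbonyl carbon affects it at all.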